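The compounds below may be only part of what the source reports. "The series", "measured", "known", "first", "only" and "open" are said of these compounds alone.

The measured compounds:
compound 1, `CCCC(=O)OC[C@H]1O[C@@H](n2cnc3c(OC)ncnc32)[C@@H](OC(=O)CCC)[C@@H]1OC(=O)CCC`, which gives 102000 nM in a physicochemical assay for solubility, in phosphate buffer; a higher number here means a more soluble compound, a lower number a less soluble compound
compound 2, `CCCC(=O)O[C@H]1[C@H](OC(=O)CCC)[C@@H](CO)O[C@H]1n1cnc2c(OC)ncnc21`, which gives 9600000 nM in this assay

Compound 1 stands lowest of the two numbers in this assay; its nearest neighbour is compound 2, reached by a 94-fold higher number from compound 1 to compound 2 (1.97 log units; beyond the scatter). Compound 3, `CCCC(=O)OC[C@H]1O[C@@H](n2cnc3c(OC)ncnc32)[C@@H](O)[C@@H]1OC(=O)CCC`, has not been measured. It differs from compound 1 by hydrogen in place of propylcarbonyl on an oxygen on a saturated carbon. Among the compounds with values here, the one measured step that bears on this change is a 94-fold higher number from compound 1 to compound 2 (1.97 log units; beyond the scatter), in which the same kind of group was likewise replaced by hydrogen at an oxygen on a saturated carbon of the same shared core, though at a different oxygen. A step in the same direction, beyond the scatter, is therefore expected for compound 3, because a 94-fold higher number from compound 1 to compound 2 (1.97 log units; beyond the scatter) shows what this replacement did once before; its size is less certain, and the expected step is a 25-fold higher number from compound 1 to compound 3 (1.39 log units; beyond the scatter). Compound 3 is accordingly expected to give about 2500000 nM in this assay, with a range from 600000 nM to 10000000 nM.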

Compound 3, solubility: 422000 nM
The estimate for compound 3 lay 5.9-fold (0.77 log units) above the measured number, outside the stated range (below it).
By their numbers in this assay, from the lowest: compound 1; then compound 3; then compound 2.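

In this assay the replacement of propylcarbonyl by hydrogen on this oxygen gives a 4.1-fold higher number from compound 1 to compound 3 (0.62 log units; beyond the scatter) and so repeats, at a second oxygen of the shared core, the direction seen before, with a step still beyond the scatter. Within the data shown here, what the earlier compounds could not show is that one and the same change, (propylcarbonyl)oxy to hydroxy, need not give one and the same size of step: at the other oxygen it gave a 94-fold higher number from compound 1 to compound 2 (1.97 log units; beyond the scatter) as a large step, while the step at this oxygen is modest. No measurement at hand speaks to the origin of this difference in size.

The compounds shown leave open what the remaining ester oxygen of the core would give under the same replacement, and what happens when more than one propylcarbonyl gives way to hydrogen. They also leave open whether a longer chain, an acetyl group or an ester carrying an amine or a carboxylic acid on this oxygen would fall between compound 1 and compound 3 or outside them.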